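A few compounds are considered here, and "the series" means these few. Any claim that something is new, unique, unknown or untested is made for them only; others in the source may bear on it.

Working notes on the series. Among the compounds with values here, compound 1 `COC(=O)/C=C/c1ccncc1-c1ccc2ccccc2c1` is the only member with a number: in a functional assay on HCT-116 cells (Homo sapiens) for inhibition, read by MTT assay, with a stated time of 72 h (on this read-out lower numbers stand for stronger inhibition of growth and higher numbers for weaker inhibition of growth), compound 1 gives 350 nM. Compound 2 `CNC(=O)COc1ccncc1-c1ccc2ccccc2c1` carries no result in this assay, its entry standing as "not determined" (no result reported), so it adds nothing to the picture. Within the data shown here, no step between two measured compounds can be drawn from the data as they stand. Compound 3 `CN1CCN(C(=O)/C=C/c2ccncc2-c2ccc3ccccc3c2)CC1` is still unmeasured; it differs from compound 1 in one place: 4-methylpiperazin-1-yl in place of methoxy on a carbonyl carbon. With a single measured number there is no basis in the series itself for the direction of this change in this assay; the expectation is a step of modest size, close to the scatter, with weaker growth inhibition taken as the slightly more likely outcome. For compound 3 in this assay the value is estimated at 500 nM, within 150 nM to 2000 nM. The step this estimate implies is expected to be a 1.4-fold higher number from compound 1 to compound 3 (0.15 log units; within the scatter).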

Compound 3, concentration for 50% growth inhibition: > 30000 nM
Compound 3 gave a limit, no number (the forecaster's own chance of this, stated with the estimate: 5%); middle value at least 60-fold (1.77 log units) from the limit.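

In this assay compound 3 gives > 30000 nM, which is a limit of the assay and not a number. Within the data shown here, the carbonyl carbon therefore does not tolerate every group: 4-methylpiperazin-1-yl in place of methoxy gives an at least 85-fold higher number from compound 1 to compound 3 (1.93 log units; beyond the scatter), a large step beyond the scatter and the first evidence that a change at this place can largely remove growth inhibition on this read-out. The full size of the step cannot be read from this result: the limit of > 30000 nM in this assay, at which 1 of the 3 values shown sits.

The two values do not separate the contribution of the piperazine ring from that of replacing the ester oxygen with a nitrogen on the carbonyl carbon. A dimethylamino group or a hydroxyl group, the latter giving the carboxylic acid, at the same carbonyl carbon would bear on that question.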